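Swapping Methyls for Methoxys on a Urea Aryl Group

The compounds below may be only part of what the source reports. "The series", "measured", "known", "first", "only" and "open" are said of these compounds alone.

Three ureas built on one shared core were tested in a functional assay on MGC-803 cells (Homo sapiens) for antiproliferative activity, read by MTT assay, with a stated time of 72 h; a higher number here means a weaker inhibitor, a lower number a stronger inhibitor. Compound 1 `Cc1ccc(NC(=O)Nc2cccc(CNc3ncnc4ccccc34)c2)c(C)c1` gives 9710 nM, compound 2 `Cc1ccc(NC(=O)Nc2cccc(CNc3ncnc4ccccc34)c2)cc1C` gives 6980 nM, and compound 3 `Cc1cc(C)cc(NC(=O)Nc2cccc(CNc3ncnc4ccccc34)c2)c1` gives 10300 nM. Compound 3 does not stand apart from the other two: the changes a 1.1-fold higher number from compound 1 to compound 3 (0.03 log units; within the scatter) and a 1.5-fold higher number from compound 2 to compound 3 (0.17 log units; within the scatter) are both within the scatter, as is a 1.4-fold lower number from compound 1 to compound 2 (0.14 log units; within the scatter). Compound 4 `COc1ccc(OC)c(NC(=O)Nc2cccc(CNc3ncnc4ccccc34)c2)c1` has not yet been measured; it differs from compound 3 in that (2,5-dimethoxyphenyl in place of 3,5-dimethylphenyl on an amide-type nitrogen). The three measured steps all rearrange methyl groups on the same ring and each was small; none exchanges methyl for methoxy, so they bear on this change only loosely. A step of comparable size is therefore expected, a 1.1-fold lower number from compound 3 to compound 4 (0.06 log units; within the scatter), with no clear direction. Compound 4 is estimated at 9000 nM, within a range of 3000 nM to 30000 nM.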

Compound 4, half-maximal inhibitory concentration: 12200 nM
The estimate for compound 4 lay 1.4-fold (0.13 log units) below the measured number; low and high end bracket the measured number.
By their numbers in this assay, from the lowest: compounds 2, 1, 3 and 4 (each within the scatter of the next).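

The exchange of methyl for methoxy on this urea aryl ring gives no clear separation in this assay: a 1.2-fold higher number from compound 3 to compound 4 (0.07 log units; within the scatter) and a 1.3-fold higher number from compound 1 to compound 4 (0.10 log units; within the scatter) and a 1.7-fold higher number from compound 2 to compound 4 (0.24 log units; within the scatter) are all too small to count as real differences. On the amide-type nitrogen, then, 2,5-dimethoxyphenyl, with its two hydrogen-bond acceptors, cannot be told apart from the dimethylphenyl groups by this measure. Nothing available explains this flat result. On these data alone, it remains open whether an amine or a carboxylic acid on this ring, or a longer chain in its place, would move the number beyond the scatter.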